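Lengthening the Amine Side Chain of Compound 2

The compounds below may be only part of what the source reports. "The series", "measured", "known", "first", "only" and "open" are said of these compounds alone.

Compound 1: `O=c1cc(-c2ccccc2)oc2cc(O)c(OCCCN3CCCCC3)c(O)c12`, 60900 nM
Compound 2: `COc1cc2oc(-c3ccccc3)cc(=O)c2c(O)c1OCCCN1CCCCC1`, 25300 nM

In a functional assay on BCG823 cells (Homo sapiens) for antiproliferative activity, read by MTT assay, with a stated time of 48 h (a higher number here means a weaker inhibitor, a lower number a stronger inhibitor), compound 1 gives 60900 nM, and compound 2 gives 25300 nM. Among the measured compounds shown here, compound 2 thus holds the lower of the two numbers; the only measured step, a 2.4-fold lower number from compound 1 to compound 2 (0.38 log units; beyond the scatter), separates it from compound 1 and is a modest change.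

The next compound, compound 3 (`COc1cc2oc(-c3ccccc3)cc(=O)c2c(O)c1OCCCCN1CCCCC1`), differs from compound 2 in one place: (piperidin-1-yl)methyl in place of piperidin-1-yl on a saturated chain carbon, three bonds along the chain from an oxygen on an aromatic ring. That is, the chain between the ring oxygen and the ring nitrogen grows by one carbon, while the methoxy and hydroxy groups of compound 2 are kept.

For the measured compounds named here, no measured step bears on this change. Going by the values given here, the one step that exists, a 2.4-fold lower number from compound 1 to compound 2 (0.38 log units; beyond the scatter), concerns a methyl on an oxygen and says nothing about chain length. With nothing in the data to push the number either way, compound 3 is expected to stay close to compound 2 in this assay, with a step of a 1.0-fold lower number from compound 2 to compound 3 (0.01 log units; within the scatter) that need not exceed the scatter. The estimate for compound 3 is therefore 25000 nM, with a range from 10000 nM to 62000 nM.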

Compound 3, half-maximal inhibitory concentration: 21900 nM
The estimate for compound 3 lay 1.1-fold (0.06 log units) above the measured number; measured number inside the range.
By their numbers in this assay, from the lowest: compounds 3 and 2 (each within the scatter of the next); then compound 1.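

In this assay, going from the 3-(piperidin-1-yl)propyl chain to the 4-(piperidin-1-yl)butyl chain on the ring oxygen gives a 1.2-fold lower number from compound 2 to compound 3 (0.06 log units; within the scatter), so compound 2 and compound 3 cannot be told apart at this position. Among the compounds shown here, the earlier step, a 2.4-fold lower number from compound 1 to compound 2 (0.38 log units; beyond the scatter), concerned only a methyl on an oxygen on an aromatic ring; this is the first reading on the chain itself, and it shows that the added carbon is accepted here without a difference beyond the scatter, unlike that methyl step. Nothing in the data offers an explanation for this result.

Going by these compounds, two chain lengths with the same amine do not describe a trend, so it remains open how a shorter 2-(piperidin-1-yl)ethyl chain or a longer chain than 4-(piperidin-1-yl)butyl would read in this assay. On these data alone, with compound 3 at 21900 nM as the reference, it is also open whether another amine, such as morpholine or diethylamine, in place of piperidin-1-yl would keep the number near that value or move it beyond the scatter.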